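The source may hold more compounds than are shown below. What is called first, only, known or untested is meant among the compounds shown, and "the series" means these compounds.

For the measured compounds named here, compound 2 `COc1ccc(-c2cc(C(=O)c3ccccc3)c(N)s2)cc1` carries the highest of the two numbers so far in an assay on CHO cells for positive allosteric modulation of adenosine receptor A1 (Homo sapiens), read by ERK phosphorylation, tested at 3 uM (on this read-out higher numbers stand for a weaker effect at the one concentration tested and lower numbers for a stronger effect), giving 31%; compound 1 `Nc1sc(-c2ccccc2)cc1C(=O)c1ccccc1` gives 12%. Going by the values given here, the one measured step, a number 19 percentage points higher from compound 1 to compound 2 (beyond the scatter), concerns the same aromatic carbon but a different group, so it bears only loosely on the next change. Compound 3 `CN(C)c1ccc(-c2cc(C(=O)c3ccccc3)c(N)s2)cc1` differs from compound 2 by dimethylamino in place of methoxy on an aromatic carbon. Among the compounds with values here, with no step of this kind measured, no direction beyond the scatter is expected; the expected step is a number 4 percentage points higher from compound 2 to compound 3 (within the scatter). Compound 3 is estimated at 35%, between 15% and 55%.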

Compound 3, a percentage reported as activity, at one concentration (the size of the read-out at that concentration, not a potency): 50%
For compound 3 the middle estimate is 15 percentage points below the measured one; the measured number falls inside the stated range.
By their numbers in this assay, from the lowest: compound 1; then compound 2; then compound 3.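

At this aromatic carbon, para to a large group, the exchange of methoxy for dimethylamino in this assay is not neutral, with a number 19 percentage points higher from compound 2 to compound 3 (beyond the scatter). Measured against hydrogen, dimethylamino gives a number 38 percentage points higher from compound 1 to compound 3 (beyond the scatter), so both groups tried here give a weaker effect than hydrogen, and dimethylamino gives the weakest of the three. No available measurement accounts for this order.

On these data alone, whether fluorine or a primary amine on this carbon would stay closer to hydrogen remains open. So does whether any group here can give a lower number than compound 1.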